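This account rests on a few compounds, and the source may have more. Where it says the series, first, only, none or still open, it means among the compounds named here.

Compound 1 `COc1ccc(-c2cc3c(cn2)[nH]c(=O)n3-c2cc(OC)c(OC)c(OC)c2)cc1F`, compound 2 `COc1ccc(-c2cc3c(cn2)[nH]c(=O)n3-c2cc(OC)c(OC)c(OC)c2)cc1O` and compound 3 `COc1ccc(-c2cc3c(cn2)[nH]c(=O)n3-c2cc(OC)c(OC)c(OC)c2)cc1N` share one core and differ in a single group on an aromatic carbon. In a functional assay on A549 cells (Homo sapiens) for antiproliferative activity, read by MTT assay, with a stated time of 48 h (a higher number here means a weaker inhibitor, a lower number a stronger inhibitor), compound 1 gives 2020 nM. In this assay, compound 2 gives 630 nM, and compound 3 gives 1140 nM. Compound 2 stands apart from compound 1, with a 3.2-fold lower number from compound 1 to compound 2 (0.51 log units; beyond the scatter), but is not separated from compound 3, with a 1.8-fold higher number from compound 2 to compound 3 (0.26 log units; within the scatter). The remaining pair shows a 1.8-fold lower number from compound 1 to compound 3 (0.25 log units; within the scatter).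

The next compound is compound 4 `COc1ccc(-c2cc3c(cn2)n(C(C)C)c(=O)n3-c2cc(OC)c(OC)c(OC)c2)cc1O`, which differs from compound 2 by isopropyl in place of hydrogen on an aromatic nitrogen of a five-membered aromatic ring with 2 nitrogen.

Among the measured compounds shown here, none of the measured steps touches that nitrogen. They show how far the series has moved so far but give no direction for this change. The central expectation in this assay is therefore no step beyond the scatter, with wide uncertainty on both sides. The expected change is a 1.3-fold lower number from compound 2 to compound 4 (0.10 log units; within the scatter). For compound 4 the estimated value is 500 nM, with an expected range of 80 nM to 3000 nM.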

Compound 4, half-maximal inhibitory concentration: 7210 nM
For compound 4 the middle estimate is 14-fold (1.16 log units) below the measured one; measured number outside the range, above it.
By their numbers in this assay, from the lowest: compounds 2, 3 and 1 (each within the scatter of the next, the first and the last beyond it); then compound 4.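

Isopropyl in place of hydrogen on an aromatic nitrogen gives, in this assay, an 11-fold higher number from compound 2 to compound 4 (1.06 log units; beyond the scatter), a large step towards a weaker inhibitor, whereas the earlier changes on an aromatic carbon gave a modest step at most. This nitrogen is therefore not indifferent to substitution, and with the hydroxy group held constant, the hydrogen there cannot be exchanged for isopropyl without a clear loss of activity. Nothing available explains this loss.

As far as these compounds go, it remains open whether the loss belongs to isopropyl alone or to any group on this nitrogen, a question that methyl or a longer chain ending in an amine could help to settle. From the compounds shown here alone, it is also open whether the same change would have a similar effect with fluoro or amino in place of hydroxy on the aromatic carbon.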